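The compounds below may be only part of what the source reports. "The series", "measured", "known", "first", "only" and "open" are said of these compounds alone.

Working notes on the series. Within the data shown here, compound 1 `Cn1cccc1-c1cc(-c2ccc(Br)cc2)[nH]c(=O)c1C#N` is the only member of the three measured compounds with a numeric result: in a functional assay on OVCAR-3 cells (Homo sapiens) for cytotoxicity, read by sulforhodamine B assay, with a stated time of 48 h (on this read-out lower numbers stand for stronger inhibition of growth and higher numbers for weaker inhibition of growth), compound 1 gives 85100 nM. Compound 2 `COc1ccc(-c2cc(-c3cccn3C)c(C#N)c(=O)[nH]2)cc1OC` reaches only the limit of this assay, > 100000 nM. Compound 3 `COc1ccc(-c2cc(-c3cccs3)[nH]c(=O)c2C#N)cc1` likewise gives only a limit, > 100000 nM. Compound 1 thus stands alone with a number; the other two values are the limit of > 100000 nM in this assay, at which 2 of the 3 values shown sit. Among the measured compounds shown here, no pair of measured compounds differs in a single place, so no measured step is available to guide the next change.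

Compound 4 `Cn1cccc1-c1cc(-c2ccc(Br)cc2)n(C(=S)Nc2ccc(F)cc2)c(=O)c1C#N` differs from compound 1 by a group of 10 heavy atoms (7 carbon, 1 nitrogen, 1 fluorine, 1 sulfur; one six-membered aromatic ring of carbon only) in place of a hydrogen atom, on an aromatic nitrogen. For the measured compounds named here, with no comparable step in hand, the size of the expected change rests on the shared core of compound 1 and the substitution alone; a gain somewhat beyond the usual scatter is expected, a 2.1-fold lower number from compound 1 to compound 4 (0.33 log units; beyond the scatter). Compound 4 is accordingly estimated at 40000 nM, with a plausible range from 10000 nM to 100000 nM.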

Compound 4, concentration for 50% growth inhibition: > 100000 nM
Compound 4 gave a limit, no number; the forecaster's own chance of this, stated with the estimate: 30%; at least 2.5-fold (0.39 log units) between middle value and limit.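

In this assay, among these compounds, the change on the aromatic nitrogen provides the first step between compounds differing in one place: an at least 1.1-fold higher number from compound 1 to compound 4 (0.07 log units; that floor lies within the scatter). The value of compound 4 is a limit, not a number, so this step is only a floor, one that lies within the scatter; it shows no gain from this substitution on the aromatic nitrogen, and the size of any loss cannot be read. With this result, the series sits mostly at one end of the read-out: the limit of > 100000 nM in this assay, at which 3 of the 4 values shown sit.

On these data alone, whether a small methyl group or an acetyl group on this aromatic nitrogen would give a numeric result remains open. Also open, as far as these compounds go, is how the core of compound 1 would respond to an amine or a carboxylic acid in place of the bromine of the 4-bromophenyl group.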